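The compounds below may be only part of what the source reports. "The series", "measured", "known", "first", "only" and "open" are said of these compounds alone.

In a functional assay on cells (Platelet, Oryctolagus cuniculus) for inhibition, read by turbidimetry, with a stated time of 5 min (a lower number here means a stronger inhibitor, a higher number a weaker inhibitor), compound 1 (`CCCC[C@@H]1NC(=O)c2ccccc21`) gives 420000 nM and is the weakest of the three inhibitors measured so far. Compound 2 (`CCCC[C@H](OC(=O)CN(C)C)c1ccccc1C(=O)O[C@H]1CO[C@H]2[C@@H]1OC[C@H]2OC(=O)c1ccccc1[C@H](CCCC)OC(=O)CN(C)C`) gives 200000 nM and compound 3 (`CCCC[C@H](OC(=O)CN1CCN(C)CC1)c1ccccc1C(=O)O[C@H]1CO[C@H]2[C@@H]1OC[C@H]2OC(=O)c1ccccc1[C@H](CCCC)OC(=O)CN1CCN(C)CC1`) gives 50000 nM in the same test. Among the measured compounds shown here, compound 4 (`CCCC[C@H]1NC(=O)c2ccccc21`) keeps every atom and bond of compound 1 (the two compounds have the same atoms and bonds and differ only in configuration as drawn: 1 of 1 stereo elements differ; a stereocentre at a saturated ring carbon is drawn S in compound 1 and R in compound 4) and a stereocentre at a saturated ring carbon is drawn R instead of S. No measured pair shows what such a swap does, so the size of this step is unknown, and no change beyond the scatter is expected in either direction. The estimate means a 1.1-fold lower number from compound 1 to compound 4 (0.02 log units; within the scatter) as the expected step. For compound 4 the expected half-maximal inhibitory concentration is 400000 nM within an estimated range from 150000 nM to 900000 nM as its limits.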

Compound 4, half-maximal inhibitory concentration: 680000 nM
Estimate against measurement, compound 4: 1.7-fold (0.23 log units) below; the range from low to high includes it.
By their numbers in this assay, from the lowest: compound 3; then compound 2; then compounds 1 and 4 (each within the scatter of the next).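

In this assay, among the compounds shown here, changing the configuration as drawn at this saturated ring carbon gives a 1.6-fold higher number from compound 1 to compound 4 (0.21 log units; within the scatter), the first measured step of this kind. At this position, the swap therefore produces no difference that this test can separate from ordinary scatter. The comparison is a clean one because a single fact holds for the pair: the fact that compounds 1 and 4 differ only in the configuration as drawn.

Still open, from the compounds shown here alone, is whether configuration here would matter with another group in place of the butyl chain, such as a longer chain or a carboxylic acid. This single pair also cannot show whether the same holds for other stereocentres.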